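Removing the drawn configuration at a compound already at the limit

The compounds below may be only part of what the source reports. "The series", "measured", "known", "first", "only" and "open" are said of these compounds alone.

Measured compounds:
Compound 1, `CC(C(=O)N1C[C@H]2CCC[C@H]2C1)N1CCN(S(=O)(=O)c2ccc(C(C)(C)C)cc2)CC1`: > 40000 nM
Compound 2, `C[C@H](C(=O)N1CCCCC1)N1CCN(S(=O)(=O)c2ccc(C(C)(C)C)cc2)CC1`: > 40000 nM

In an ADME assay on HepG2 cells (Homo sapiens) for inhibition, with a stated time of 48 h (on this read-out lower numbers stand for an effect already at smaller amounts and higher numbers for an effect only at larger amounts of compound), compound 1 reaches only the limit of the measurement, > 40000 nM. Compound 2 likewise gives only a limit, > 40000 nM. Both values shown therefore sit at one line, (the limit of > 40000 nM in this assay, at which 2 of the 2 values shown sit). Compound 3, `CC(C(=O)N1CCCCC1)N1CCN(S(=O)(=O)c2ccc(C(C)(C)C)cc2)CC1`, has the same atoms and bonds as compound 2; the single stereocentre at a saturated chain carbon is drawn R in compound 2 and without a configuration in compound 3 (the two compounds have the same atoms and bonds; at least one stereo element is drawn with a configuration in one of them and without one in the other: 1 of 1 stereo elements differ; a stereocentre at a saturated chain carbon is drawn R in compound 2 and without a configuration in compound 3). No change beyond the usual scatter is expected from this step, so the estimated step of a number no higher from compound 2 to compound 3 (the limit leaves the size open) is flat. Compound 3 is expected at 40000 nM, between 20000 nM and 80000 nM, most likely again as a limit.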

Compound 3, half-maximal effective concentration: > 40000 nM
Compound 3 was reported as a limit; the forecaster's own chance of this, stated with the estimate: 85%; the middle value sits exactly at the limit.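

Compound 3 gives only a limit, > 40000 nM, so neither its step from compound 1 nor its step from compound 2 can be read: the limit of > 40000 nM in this assay, at which 3 of the 3 values shown sit.

As far as these compounds go, what stays open is whether the drawn configuration or the exchanged ring group makes any difference to the read-out.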